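Swapping the dichlorophenyl for a fluorophenyl on sulfur

The source may hold more compounds than are shown below. What is called first, only, known or untested is meant among the compounds shown, and "the series" means these compounds.

Of the compounds shown here, two of a shared core have been measured so far. Compound 1 `Nc1cc(N)c2nc(-c3ccccc3)c(Oc3ccc(Cl)c(Cl)c3)nc2c1` gives 24000 nM in a functional assay on SR cells (Homo sapiens) for inhibition, read by sulforhodamine B assay, with a stated time of 48 h; a lower number here means a stronger inhibitor of growth, a higher number a weaker inhibitor of growth. Compound 2 `Nc1cc(N)c2nc(-c3ccccc3)c(Sc3ccc(Cl)c(Cl)c3)nc2c1` gives 35500 nM in this assay; this is the higher of the two numbers, but the step from compound 1 to compound 2, a 1.5-fold higher number from compound 1 to compound 2 (0.17 log units; within the scatter), lies within the scatter, so the two cannot be told apart. Compound 3 `Nc1cc(N)c2nc(-c3ccccc3)c(Sc3ccc(F)cc3)nc2c1` has not been measured. It differs from compound 2 by 4-fluorophenyl in place of 3,4-dichlorophenyl on a sulfur. Going by the values given here, no measured step changes this place: the only step available alters the atom that joins the ring to the core, not the ring itself, and was within the scatter. The expectation therefore rests on compound 2 alone, and the step from compound 2 to compound 3 is expected to be a 1.0-fold lower number from compound 2 to compound 3 (0.01 log units; within the scatter), with no clear direction. Compound 3 is estimated at 35000 nM, within a range from 9000 nM to 130000 nM in this assay.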

Compound 3, concentration for total growth inhibition: < 100000 nM
Compound 3: no number, only a limit; the forecaster's own chance of this, stated with the estimate: 20%; the middle value is on the limit's open side.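

In this assay compound 3 gives < 100000 nM, which is a limit and not a number, so its steps from compound 1 and from compound 2 cannot be read. The compounds shown leave open whether 4-fluorophenyl in place of 3,4-dichlorophenyl on a sulfur changes growth inhibition, and in which direction.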